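This account rests on a few compounds, and the source may have more. Where it says the series, first, only, none or still open, it means among the compounds named here.

Working notes on the solubility series.

Of the compounds shown here, three of the shared core have been measured in a physicochemical assay for solubility; a lower number here means a less soluble compound, a higher number a more soluble compound. Compound 1 `CNC(=O)c1cc(C(=O)NC2CCC2)cn(Cc2cccnc2)c1=O` gives >= 99 ug/mL in this assay, which is a limit of the assay rather than a number. Compound 3 `CNC(=O)c1cc(C(=O)NC2CCOCC2)cn(Cc2ccccc2)c1=O` gives >= 174 ug/mL in this assay, again a limit. Compound 2 `CNC(=O)c1cc(C(=O)NC2CC2)cn(Cc2ccc3nc[nH]c3c2)c1=O` gives >= 163 ug/mL in this assay, and this too is a limit. Among the compounds with values here, compound 2 therefore stands among three values of which each is only a limit, so no step between measured compounds can be sized, and no ordering of the three is possible on these numbers; the lines (the limit of >= 163 ug/mL in this assay, at which 1 of the 3 values shown sits), the limit of >= 174 ug/mL in this assay, at which 1 of the 3 values shown sits, and the limit of >= 99 ug/mL in this assay, at which 1 of the 3 values shown sits, each hold one of the three values.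

Compound 4 `CNC(=O)c1cc(C(=O)NC2CC2)cn(Cc2cccc([C@@H](C)O)c2)c1=O` is not yet measured in this assay. It differs from compound 2 in one place: 3-(1-hydroxyethyl)phenyl in place of 1H-benzimidazol-6-yl on a saturated chain carbon bound to an aromatic nitrogen. Since compound 2 sits only at a limit, the size of the step from compound 2 to compound 4 cannot be read from any measured pair. Compound 4 is expected to remain soluble, with an estimated value of 150 ug/mL, between 60 ug/mL and 300 ug/mL, so that the expected step of an at least 1.0-fold lower number from compound 2 to compound 4 (0.03 log units; that floor lies within the scatter) should be no larger than the usual scatter, and a limit rather than a number is again likely to be reported.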

Compound 4, solubility: >= 131 ug/mL
Compound 4: a limit, no number; the forecaster's own chance of this, stated with the estimate: 60%; the middle value does not contradict the limit.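

In this assay compound 4 gives >= 131 ug/mL, which is a limit and not a number. Compound 2 also stands at a limit, >= 163 ug/mL, so the step between these two compounds cannot be read. The compounds shown leave open whether 3-(1-hydroxyethyl)phenyl in place of 1H-benzimidazol-6-yl changes the read-out at all.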